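Aldehyde oxidase stability: aminoquinoline side-chain variants

This account rests on a few compounds, and the source may have more. Where it says the series, first, only, none or still open, it means among the compounds named here.

Measured so far:
compound 1 `Cn1cc(-c2ccc3nnc(Sc4ccc5ncc(NCC6CCOC6)cc5c4)n3c2)cn1`: 1.63 h
compound 2 `Cn1cc(-c2ccc3nnc(Sc4ccc5ncc(NCCO)cc5c4)n3c2)cn1`: 0.25 h

In an ADME assay on cytosol from liver (strain CD1) for pharmacokinetics, with aldehyde oxidase 1 (Mus musculus) as the target, read by LC-MS, with a stated time of 120 min, tested at 1 uM (a lower number here means that the compound disappears faster, a higher number that the compound lasts longer), compound 2 gives 0.25 h, the lowest of the two numbers; the nearest is compound 1, which in this assay gives 1.63 h, a higher number beyond the scatter. For the measured compounds named here, the single measured step, a 6.5-fold lower number from compound 1 to compound 2 (0.81 log units; beyond the scatter), replaces an oxolan-3-yl with a hydroxymethyl on a saturated chain carbon bound to the aromatic nitrogen.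

Compound 3 `Cn1cc(-c2ccc3nnc(Sc4ccc5ncc(NC6COC6)cc5c4)n3c2)cn1` has not yet been measured. The change from compound 2 is oxetan-3-yl in place of 2-hydroxyethyl on a nitrogen on an aromatic ring. This partly reverses the measured step: the hydroxyl donor leaves and a cyclic ether returns, though now attached directly to the nitrogen rather than through a chain carbon. Going by the values given here, the only bearing step, a 6.5-fold lower number from compound 1 to compound 2 (0.81 log units; beyond the scatter), was modest but clear, so the expectation is a gain in this assay for compound 3, smaller than the full reversal since the substituent differs from that of compound 1. Compound 3 is estimated at 0.8 h, with a range of 0.3 h to 2.5 h, which corresponds to an expected step of a 3.2-fold higher number from compound 2 to compound 3 (0.51 log units; beyond the scatter).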

Compound 3, half-life: 0.733 h
Estimate against measurement, compound 3: 1.1-fold (0.04 log units) above; the range from low to high includes it.
By their numbers in this assay, from the lowest: compound 2; then compound 3; then compound 1.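

In this assay, the step of a 2.9-fold higher number from compound 2 to compound 3 (0.47 log units; beyond the scatter) shows that a gain at this nitrogen does not need the (oxolan-3-yl)methyl group of compound 1: an oxetan-3-yl, a four-membered ring with no chain carbon, also moves the number up when it replaces 2-hydroxyethyl. The step of a 2.2-fold lower number from compound 1 to compound 3 (0.35 log units; beyond the scatter) shows that this gain stops short of the number for compound 1, so among these substituents a cyclic ether on the side chain is not enough by itself to reach the top of the series, and the order across the three compounds puts the two cyclic ethers above the open-chain alcohol, with no compound shown against that order. Nothing measured here accounts for either step.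

Oxetan-3-yl and (oxolan-3-yl)methyl differ both in the ring and in the chain carbon, so the two contributions remain unseparated; an (oxetan-3-yl)methyl or an oxolan-3-yl group on the same nitrogen would divide them. A 2-methoxyethyl group would show whether capping the hydroxyl of the open chain gives a similar gain without any ring.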